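Adding a second chloro to the pendant aromatic ring

The compounds below may be only part of what the source reports. "The series", "measured", "known", "first", "only" and "open" are said of these compounds alone.

Measured compounds:
compound 1 `O=C1OC(c2ccc(Cl)cc2)=C/C1=C\c1ccccc1Cl` — 81.5%
compound 2 `O=C1OC(c2ccc(Cl)cc2)=C/C1=C\c1ccccc1[N+](=O)[O-]` — 18.5%

Within the data shown here, in a functional assay on the whole organism (strain Wistar) for inhibition, with Rattus norvegicus as the target, with stated times of 30 min and 3 h, at a dose of 20 mg/kg by the oral route (a higher number here means more inhibition at the dose given (going by the name of the read-out), a lower number less inhibition), compound 1 stands highest of the two numbers measured, with compound 2 the nearest, and the step of a number 63 percentage points lower from compound 1 to compound 2 (beyond the scatter) describes the only change recorded, nitro in place of chloro on an aromatic carbon. Compound 3 `O=C1OC(c2ccc(Cl)cc2)=C/C1=C\c1ccc(Cl)cc1Cl` is not yet measured. It differs from compound 1 by chloro in place of hydrogen on an aromatic carbon. Among the measured compounds shown here, no measured step removes or adds a hydrogen on this ring, so the single recorded step bears only loosely on it: it shows that this ring is sensitive to a change of group, but a second chloro is not the same change as a nitro. The step is therefore expected to be small, not beyond the scatter, as a number 6.5 percentage points lower from compound 1 to compound 3 (within the scatter). Compound 3 is estimated at 75%, with a range from 50% to 95%.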

Compound 3, a percentage reported as inhibition, in the whole organism at one dose (the size of the read-out at that dose, not a potency): 72.6%
The estimate for compound 3 lay 2.4 percentage points above the measured number; the range from low to high includes it.
By their numbers in this assay, from the lowest: compound 2; then compounds 3 and 1 (each within the scatter of the next).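

In this assay the added chloro, meta to a chloro group and para to a large group, comes with a number 8.9 percentage points lower from compound 1 to compound 3 (within the scatter) and so makes no difference that can be told from the scatter. Among these compounds, this is the first sign that the pendant ring can take a further substituent at this carbon and keep its inhibition at the dose given, whereas the earlier step, a number 63 percentage points lower from compound 1 to compound 2 (beyond the scatter), was a replacement of the existing chloro and not an addition at a new carbon. No measurement shown here gives a reason for either step.

The compounds shown leave open how an amine, a carboxylic acid or a methoxy group would behave at this same carbon. They also leave open whether a nitro group placed here would match the large step seen at the other position.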